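This account rests on a few compounds, and the source may have more. Where it says the series, first, only, none or still open, it means among the compounds named here.

Compound 1 `Cc1ccc(C(=O)N2CCN(c3nc(=O)c4cc(C(F)(F)F)cc([N+](=O)[O-])c4s3)CC2)cc1`: > 125000 nM
Compound 2 `CC(C)(C)C(=O)N1CCN(c2nc(=O)c3cc(C(F)(F)F)cc([N+](=O)[O-])c3s2)CC1`: > 125000 nM

Both measured compounds share one core and differ only in the group on the carbonyl carbon. In an ADME assay on Vero cells (Chlorocebus sabaeus) for cytotoxicity, read by MTT assay, with a stated time of 72 h (on this read-out higher numbers stand for lower toxicity in this test and lower numbers for higher toxicity in this test), compound 1 gives > 125000 nM, which is a limit of the test and not a number. In this assay compound 2 gives > 125000 nM, again a limit rather than a number. The step that the two limits leave unreadable from compound 1 to compound 2 therefore cannot be read, since both values sit at the limit of > 125000 nM in this assay, at which 2 of the 2 values shown sit. Going by the values given here, compound 2 stands at that limit, and so does the only other value shown.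

Compound 3 `CCC(C)C(=O)N1CCN(c2nc(=O)c3cc(C(F)(F)F)cc([N+](=O)[O-])c3s2)CC1` has not yet been measured in this assay. It differs from compound 2 by sec-butyl in place of tert-butyl on a carbonyl carbon; the two have the same atoms, joined differently. Among the compounds with values here, the only measured step, a step that the two limits leave unreadable from compound 1 to compound 2, which put a tert-butyl in place of a 4-methylphenyl, left both ends at the limit and so gives no size to carry over. With the same atoms merely rearranged, the step that the limit leaves unreadable from compound 2 to compound 3 is expected to be none beyond the scatter, most likely ending at the limit once more. For compound 3 the estimate is 150000 nM, ranging from 60000 nM to 400000 nM.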

Compound 3, half-maximal cytotoxic concentration: > 125000 nM
Compound 3 was reported as a limit (the forecaster's own chance of this, stated with the estimate: 85%); the middle value is on the limit's open side.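

In this assay compound 3 gives > 125000 nM, again a limit of the test and not a number. The steps among compound 1, compound 2 and compound 3 therefore cannot be read: the limit of > 125000 nM in this assay, at which 3 of the 3 values shown sit. The compounds shown leave open whether changing the group on the carbonyl carbon alters the result in this assay at all.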